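The source may report more compounds than this note shows. Statements on the series, on what has been measured and on what is new or still open speak of the compounds shown alone.

Measured so far:
- compound 1 `C=C(Br)C(=O)Nc1cccc(-c2cn3nc(-c4ccccc4)sc3n2)c1`: 600 nM
- compound 2 `COc1ccc(-c2nn3cc(-c4cccc(N)c4)nc3s2)cc1OC`: 16000 nM
- compound 3 `Nc1cccc(-c2cn3nc(-c4ccccc4)sc3n2)c1`: 32000 nM

In a functional assay on L1210 cells (Mus musculus) for inhibition, read by cell counting, with a stated time of 2 days (on this read-out lower numbers stand for stronger inhibition and higher numbers for weaker inhibition), compound 1 gives the lowest of the three numbers, with compound 2 and compound 3 both far higher. Among the measured compounds shown here, the only single-step comparison, a 53-fold higher number from compound 1 to compound 3 (1.73 log units; beyond the scatter), concerns the bromoacrylamide, not the change considered here. Compound 4 `C=C(Br)C(=O)Nc1cccc(-c2cn3nc(-c4ccc(OC)cc4)sc3n2)c1` differs from compound 1 by methoxy in place of hydrogen on an aromatic carbon. For the measured compounds named here, no measured step covers this change directly; the closest hint is that compound 2, with two methoxy groups on that ring, and compound 3, without them, give numbers within the usual scatter of each other. The expectation is therefore a 1.2-fold higher number from compound 1 to compound 4 (0.07 log units; within the scatter), nothing beyond the scatter. Compound 4 is estimated at 700 nM, in the range 250 nM to 2000 nM.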

Compound 4, half-maximal inhibitory concentration: 940 nM
Beside the measured number, compound 4's estimate is 1.3-fold (0.13 log units) below it, and the stated range covers the measured number.
By their numbers in this assay, from the lowest: compounds 1 and 4 (each within the scatter of the next); then compounds 2 and 3 (each within the scatter of the next).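

Methoxy in place of hydrogen, on the six-membered aromatic ring and para to a large group, gives a 1.6-fold higher number from compound 1 to compound 4 (0.19 log units; within the scatter) in this assay. Among the compounds shown here, this is the first direct reading of this change with the (1-bromoethenyl)carbonyl group kept, and the ring position accepts methoxy with no difference that can be told from scatter. No measured evidence here accounts for this result.

From the compounds shown here alone, whether an amine, a carboxylic acid or a longer chain such as butoxy at the same position would also leave the number within the scatter stays open.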